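A Nitro for a Methyl on a Weakly Active Amide

The source may report more compounds than this note shows. Statements on the series, on what has been measured and on what is new or still open speak of the compounds shown alone.

Compound 1, `COc1ccc2sc(NC(=O)c3ccc(C)cc3)nc2c1`, is an amide built on a shared core. In a functional assay on SK-HEP1 cells (Homo sapiens) for antiproliferative activity, read by sulforhodamine B assay (a lower number here means a stronger inhibitor of growth, a higher number a weaker inhibitor of growth), compound 1 gives > 10 ug/mL, which is a limit of the assay rather than a number. Two related compounds sit at the same place. Compound 2, `COc1cccc2sc(NC(=O)c3ccc([N+](=O)[O-])cc3)nc12`, in this assay gives > 10 ug/mL, also a limit. Compound 3, `COc1ccc(NC(=O)Nc2nc3ccc(F)cc3s2)cc1`, a urea on a related core, in this assay gives > 10 ug/mL, again a limit. the limit of > 10 ug/mL in this assay, at which 3 of the 3 values shown sit, sums this up: none of the three has a measured number, so compound 1 cannot be ranked against the others. The new compound 4, `COc1ccc2sc(NC(=O)c3ccc([N+](=O)[O-])cc3)nc2c1`, differs from compound 1 by nitro in place of methyl on an aromatic carbon, para to a large group. No measured step between any two of these compounds exists to guide the change. The expectation is that a step that the limit leaves unreadable from compound 1 to compound 4 stays within the scatter, with the result most likely reported once more as a limit. Compound 4 is therefore estimated at 15 ug/mL, within 8 ug/mL to 40 ug/mL.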

Compound 4, concentration for 50% growth inhibition: > 10 ug/mL
Compound 4: only a limit was reported; the forecaster's own chance of this, stated with the estimate: 85%; the middle value lies beyond the limit too.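

Going by these compounds alone, compound 4 sits at the same assay limit as compound 1, so no step between them can be read: the limit of > 10 ug/mL in this assay, at which 4 of the 4 values shown sit. The compounds shown leave open whether, in this assay, any change to these structures would give a measured number rather than a limit.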